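A Pyridine Ring in Place of a Methyl Group

This account rests on a few compounds, and the source may have more. Where it says the series, first, only, none or still open, it means among the compounds named here.

In a functional assay (aorta) with Rattus norvegicus as the target (on this read-out higher numbers stand for an effect only at larger amounts of compound and lower numbers for an effect already at smaller amounts), compound 1 `COc1ccc(-c2nc(/N=C(\N)NC(C)C)sc2-c2ccc(OC)cc2)cc1` gives 9.1 uM and compound 2 `COc1ccc(-c2nc(/N=C(\N)N3CCOCC3)sc2-c2ccc(OC)cc2)cc1` gives 66 uM. On the same shared core, compound 3 `COc1ccc(-c2nc(CNC(C)=O)sc2-c2ccc(OC)cc2)cc1` gives 8.1 uM. It sits level with compound 1, as a 1.1-fold lower number from compound 1 to compound 3 (0.05 log units; within the scatter) shows, and clear of compound 2, as an 8.1-fold lower number from compound 2 to compound 3 (0.91 log units; beyond the scatter) shows.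

Compound 4 `COc1ccc(-c2nc(CNC(=O)c3cccnc3)sc2-c2ccc(OC)cc2)cc1` keeps everything in compound 3 except for one change: pyridin-3-yl in place of methyl on a carbonyl carbon. Within the data shown here, no measured step makes this exact exchange, and compound 3 is the only measured compound with this amide. The nearest evidence is indirect. Exchanging the group on the carbon with a double bond to nitrogen moved the number, with a 7.3-fold higher number from compound 1 to compound 2 (0.86 log units; beyond the scatter), so a change far out on the side chain can matter. That step is a modest one and involves a different group, so only a small shift with a slight lean upward is expected, and the uncertainty stays wide. The expected step is a 1.5-fold higher number from compound 3 to compound 4 (0.17 log units; within the scatter). For compound 4 the estimated value is 12 uM, with an expected range from 3.5 uM to 42 uM.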

Compound 4, concentration for half-maximal effect: 8.2 uM
Compound 4: middle estimate off by 1.5-fold (0.17 log units), on the high side; the measured number falls inside the stated range.
By their numbers in this assay, from the lowest: compounds 3, 4 and 1 (each within the scatter of the next); then compound 2.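

On the carbonyl carbon, pyridin-3-yl stands level with methyl in this assay, with a 1.0-fold higher number from compound 3 to compound 4 (0.01 log units; within the scatter), so at this position the measured number does not separate the aromatic ring from the single carbon it replaces. The longer amide side chain also stays level with the group on the aromatic carbon in the isopropylamino compound, with a 1.1-fold lower number from compound 1 to compound 4 (0.05 log units; within the scatter). It remains clear of the morpholin-4-yl group, with an 8.0-fold lower number from compound 2 to compound 4 (0.91 log units; beyond the scatter), so adding the ring does not carry the number towards the highest value of the series.

Going by these compounds, it remains open whether phenyl, pyridin-2-yl, an amine or a longer alkyl chain on the same carbonyl carbon would stay level as well. Nothing shown here accounts for the lack of a shift between methyl and pyridin-3-yl.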